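This account rests on a few compounds, and the source may have more. Where it says the series, first, only, none or still open, it means among the compounds named here.

Measured compounds in a functional assay on UO-31 cells (Homo sapiens) for inhibition, read by sulforhodamine B assay, tested at 10 uM; on this read-out lower numbers stand for less inhibition and higher numbers for more inhibition at the one concentration tested (going by the name of the read-out):
compound 1, `COc1cc2oc(-c3cccc(NC(=O)c4ccc(C(F)(F)F)cc4)c3)cc(=O)c2c(OC)c1OC`, gives "active" (no number reported)
compound 2, `COc1cc2oc(-c3cccc(NC(=O)c4ccc(F)cc4)c3)cc(=O)c2c(OC)c1OC`, gives "active" (no number reported)
compound 3, `COc1cc2oc(-c3cccc(NC(=O)c4ccc(Cl)cc4)c3)cc(=O)c2c(OC)c1OC`, gives 51.1%

All three share one core and differ only in the group at the far end of the amide. For compound 1 and compound 2 the result is recorded only as active, without a number, so neither can be set against the others in size. For the measured compounds named here, compound 3 is therefore the only one of the three with a number, and it stands alone: no step between any two measured compounds can be given, and nothing shows how much the group at the far end of the amide moves the inhibition.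

Compound 4, `COc1cc2oc(-c3cccc(NC(=O)c4ccc(C#N)cc4)c3)cc(=O)c2c(OC)c1OC`, has not yet been tested. It differs from compound 3 in one place: cyano in place of chloro on an aromatic carbon.

Going by the values given here, with no measured step to lean on, the expectation rests on the single value of compound 3. A change of this kind is expected to shift the inhibition in this assay only modestly, if at all, most likely downward and close to the scatter. The step of a number 9.1 percentage points lower from compound 3 to compound 4 (within the scatter) is the estimated size of that change. On that basis compound 4 is expected to give about 42%, with a range from 20% to 65%.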

Compound 4, a percentage reported as inhibition, at one concentration (the size of the read-out at that concentration, not a potency): "active" (no number reported)
Nothing numeric was reported for compound 4; the estimate stays without a comparison.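

In this assay compound 4 gives "active" (no number reported) and so, like compound 1 and compound 2, cannot be set in size against compound 3, which means no new step can be read. Nothing shown offers an explanation for this result. Still open, as far as these compounds go, is how much the group at the far end of the amide changes the inhibition.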